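From 1-methyl-1H-pyrrol-2-yl to 1-methyl-1H-pyrazol-3-yl

The compounds below may be only part of what the source reports. "The series", "measured", "known", "first", "only" and "open" are said of these compounds alone.

Three compounds have been measured in a functional assay with Alpha-1A adrenergic receptor (Homo sapiens) as the target, read by calcium flux; on this read-out lower numbers stand for smaller maximal responses and higher numbers for larger maximal responses:

Compound 1 `Cc1ccc(-c2ccccc2NCC2=NCCN2)n1C`: 78%
Compound 2 `Cn1cccc1-c1ccccc1NCC1=NCCN1`: 103%
Compound 3 `CCn1cccc1-c1ccccc1NCC1=NCCN1`: 93%

Compound 2 sits at the top of these three numbers. The step from compound 1 is a number 25 percentage points higher from compound 1 to compound 2 (beyond the scatter), and it lies beyond the scatter. The step to compound 3 is a number 10 percentage points lower from compound 2 to compound 3 (within the scatter), within the scatter, so compound 2 and compound 3 cannot be told apart.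

Compound 4 `Cn1ccc(-c2ccccc2NCC2=NCCN2)n1` differs from compound 2 in one place: 1-methyl-1H-pyrazol-3-yl in place of 1-methyl-1H-pyrrol-2-yl on an aromatic carbon. Both measured steps touch the same five-membered ring and its surroundings. One of them, a number 25 percentage points higher from compound 1 to compound 2 (beyond the scatter), shows that a change on that ring can shift the maximal response beyond the scatter, while the other, a number 10 percentage points lower from compound 2 to compound 3 (within the scatter), stays within it. Swapping one ring for another is a larger alteration than either, so a shift in the maximal response is possible, and a small downward step is expected: a number 11 percentage points lower from compound 2 to compound 4 (beyond the scatter). Compound 4 is therefore estimated at 92%, with a range from 65% to 115%.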

Compound 4, largest response reached (reported as maximal response), in percent of the reference or control that the assay uses: 116%
Estimate against measurement, compound 4: 24 percentage points below; the measured number lies above the stated range.
By their numbers in this assay, from the lowest: compound 1; then compounds 3 and 2 (each within the scatter of the next); then compound 4.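

In this assay, within the data shown here, the earlier steps changed only small alkyl groups on the five-membered aromatic ring, whereas this one exchanges the ring itself. Putting 1-methyl-1H-pyrazol-3-yl in place of 1-methyl-1H-pyrrol-2-yl gives a number 13 percentage points higher from compound 2 to compound 4 (beyond the scatter), so this position accepts a ring with 2 hetero atoms instead of 1, and the response does not fall. This is a single ring exchange and a modest step, and nothing measured here explains the rise.

As far as these compounds go, it remains open whether a triazole ring, with one more ring nitrogen, would continue this rise or reverse it. Also open, from the compounds shown here alone, is how the 1-methyl-1H-pyrazol-3-yl ring would respond to a longer chain such as propyl on its nitrogen, or to an amine on one of its carbons.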